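Amide for Ester on the Chain Hanging from Nitrogen

The compounds below may be only part of what the source reports. "The series", "measured", "known", "first", "only" and "open" are said of these compounds alone.

Three compounds have been taken through a functional assay on T47D cells (Homo sapiens) for cytotoxicity, read by colorimetric assay and MTT assay; on this read-out lower numbers stand for stronger inhibition and higher numbers for weaker inhibition. Compound 1 `COc1ccc2cc(-c3ccccc3)c(O)nc2c1` gives 10000 nM in this assay. Compound 2 `COc1cc(OC)c2cc(-c3ccc(OCc4ccccc4)cc3)c(O)nc2c1` gives 10000 nM in this assay. Compound 3 `CCOC(=O)Cn1c(=O)c(-c2ccc(OC)cc2)cc2c(OC)cc(OC)cc21` gives 10000 nM in this assay, so compound 3 stands level with compounds 1 and 2 at the digits shown, and the three values lie within the scatter of one another; none of them can be called more or less potent than the others.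

The next compound, compound 4 `CCN(CC)C(=O)CCn1c(=O)c(-c2ccc(OC)cc2)cc2c(OC)cc(OC)cc21`, is not yet measured in this assay. It differs from compound 3 in one place: (diethylcarbamoyl)methyl in place of ethoxycarbonyl on a saturated chain carbon bound to an aromatic nitrogen. For the measured compounds named here, nothing among the measured compounds tells how such a change on this chain moves the read-out, since no two of them differ in a single place.

With all three measured compounds sitting at the same value, the only ground for an expectation is that compound 4 keeps the core and both methoxy groups of compound 3 unchanged. The step of no change at the digits printed from compound 3 to compound 4 (within the scatter) is therefore expected to be none beyond the scatter, in neither direction. Compound 4 is estimated at 10000 nM in this assay, with a range from 5000 nM to 20000 nM.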

Compound 4, half-maximal inhibitory concentration: 10000 nM
For compound 4 middle estimate and measured number coincide at the digits printed; low and high end bracket the measured number.
By their numbers in this assay, from the lowest: compounds 1, 2, 3 and 4 (each within the scatter of the next).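

In this assay, for the compounds shown here, the first step that can be read at this position is flat, with no change at the digits printed from compound 3 to compound 4 (within the scatter). Cut one bond further out, the same difference reads (ethoxycarbonyl)methyl to 2-(diethylcarbamoyl)ethyl, so the single step exchanges ester for amide and also alters the chain, and the read-out does not separate the two. It does show that a group of 8 heavy atoms with 1 hydrogen-bond acceptor can replace one of 5 heavy atoms with 2 hydrogen-bond acceptors at this place with no shift in the number, though nothing shown offers an explanation for this outcome.

The compounds shown leave open whether the amide on the chain length of compound 3, or a carboxylic acid or an amine at the end of this chain, would give a read-out different from that of compound 4 at 10000 nM. They also leave open whether any group at this place can move the number at all, as all four compounds print the same value and no other step can be read.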